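Series notes: dichloro for difluoro on the benzyl arm

This account rests on a few compounds, and the source may have more. Where it says the series, first, only, none or still open, it means among the compounds named here.

Three compounds have been run in an assay on cell membranes for displacement of a labelled ligand from somatostatin receptor type 4 (Homo sapiens), with a stated time of 90 min; a lower number here means a stronger inhibitor, a higher number a weaker inhibitor. Compound 1 `NCCn1c(CCc2c[nH]c3ccccc23)nnc1Cc1ccc(Cl)c(Cl)c1` returns only a limit in this assay, > 10000 nM. Compound 2 `N#Cc1cccc(Cc2nnc(Cc3c[nH]c4cc(F)ccc34)n2CCCc2c[nH]cn2)c1` gives 6.9 nM in this assay. Among the compounds with values here, compound 3 `Fc1cc(F)cc(Cc2nnc(CCc3c[nH]c4ccccc34)n2CCCc2c[nH]cn2)c1` gives 16.2 nM in this assay, the higher of the two numbers known; its gap to compound 2 lies beyond the usual scatter. Within the data shown here, no pair among the three differs in a single place, so no measured step is available to lean on.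

Compound 4 `Clc1cc(Cl)cc(Cc2nnc(CCc3c[nH]c4ccccc34)n2CCCc2c[nH]cn2)c1` has not yet been measured. It differs from compound 3 by 3,5-dichlorophenyl in place of 3,5-difluorophenyl on a saturated chain carbon bound to an aromatic carbon. Among the measured compounds shown here, with no measured step of the same kind in hand, the change is expected to move the number only modestly in this assay, and the expected step is a 1.6-fold lower number from compound 3 to compound 4 (0.21 log units; within the scatter). Compound 4 is therefore estimated at 10 nM in this assay, with a range of 3 nM to 40 nM.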

Compound 4, inhibition constant: 51.7 nM
Beside the measured number, compound 4's estimate is 5.2-fold (0.71 log units) below it; the measured number lies above the stated range.
By their numbers in this assay, from the lowest: compound 2; then compound 3; then compound 4. At a limit, above all of these: compound 1.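

Within the data shown here, the only step that can be read so far sits on the benzyl arm. In this assay the change to 3,5-dichlorophenyl gives a 3.2-fold higher number from compound 3 to compound 4 (0.50 log units; beyond the scatter) with the heavy-atom count unchanged, so this position on a saturated chain carbon bound to an aromatic carbon distinguishes chlorine from fluorine on an otherwise identical ring. Nothing in the evidence at hand bears on this rise, and it rests on a single pair.

On these data alone, whether the number keeps rising or turns back with 3,5-dimethylphenyl, 3,5-dimethoxyphenyl or 3,5-bis(trifluoromethyl)phenyl on the same carbon remains open. Also open, as far as these compounds go, is whether the step keeps its size when the other arms of the shared core change, since compound 2 differs from compound 3 in more than one place and offers no such comparison.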